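Thiophen-3-yl in place of pyridin-3-yl on compound 3

A few compounds are considered here, and "the series" means these few. Any claim that something is new, unique, unknown or untested is made for them only; others in the source may bear on it.

Of the compounds shown here, three have values so far in a functional assay on A-375 cells (Homo sapiens) for activation, with a stated time of 3 days; on this read-out lower numbers stand for an effect already at smaller amounts and higher numbers for an effect only at larger amounts of compound. Compound 1 (`O=C(Nc1ccc(-c2cscn2)cc1)C1CCN(Cc2ccc(F)c(F)c2)C1`) gives 8000 nM, and compound 2 (`O=C(Nc1ccc(-c2cscn2)cc1)C1CCCN(Cc2cccc(F)c2F)C1`) gives 10000 nM. Compound 3 (`O=C(Nc1ccc(-c2cccnc2)cc1)C1CCCN(Cc2ccc(F)c(F)c2)C1`) gives 1060 nM, the lowest of the three numbers, and its gaps to the other two both lie beyond the scatter. Among the measured compounds shown here, compound 1 and compound 2 each differ from compound 3 in more than one place, and the series holds no measured step that changes a single place.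

Compound 4 (`O=C(Nc1ccc(-c2ccsc2)cc1)C1CCCN(Cc2ccc(F)c(F)c2)C1`) has thiophen-3-yl in place of pyridin-3-yl on an aromatic carbon, para to a large group: thiophen-3-yl in place of pyridin-3-yl on an aromatic carbon. For the measured compounds named here, no measured compound tests this exchange alone, so the expectation is loose. Compound 3 at 1060 nM is the lowest point so far, and a modest move toward a higher number seems more likely than a lower one. The expected step is a 2.4-fold higher number from compound 3 to compound 4 (0.37 log units; beyond the scatter). For compound 4, the estimated value is 2500 nM, with an expected range of 800 nM to 8000 nM.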

Compound 4, half-maximal effective concentration: 1930 nM
Compound 4: middle estimate off by 1.3-fold (0.11 log units), on the high side, within the range that was stated.
By their numbers in this assay, from the lowest: compounds 3 and 4 (each within the scatter of the next); then compounds 1 and 2 (each within the scatter of the next).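

In this assay, among the compounds shown here, thiophen-3-yl in place of pyridin-3-yl on an aromatic carbon, para to a large group, gives a 1.8-fold higher number from compound 3 to compound 4 (0.26 log units; within the scatter) and this is the first single-place step. At this position, a five-membered aromatic ring with sulfur as its hetero atom therefore reads the same within the scatter as a six-membered aromatic ring with nitrogen as its hetero atom. No measurement at hand accounts for this result.

Going by these compounds, whether a plain phenyl ring, or an aromatic ring carrying an amine or a carboxylic acid, would hold the same level at this position remains open. Compound 1 and compound 2 each differ from compound 3 in more than one place, so their steps cannot be read.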